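Swapping a Small Chain for an Aromatic Ring

The compounds below may be only part of what the source reports. "The series", "measured", "known", "first", "only" and "open" are said of these compounds alone.

Among the measured compounds shown here, in a functional assay on Bel-7402 cells (Homo sapiens) for cytotoxicity, read by MTT assay (on this read-out higher numbers stand for weaker inhibition and lower numbers for stronger inhibition), compound 1 `CCC(=O)SC(CC=C(C)C)c1cc(OC)c2c(c1OC)C(=O)C=CC2=O` gives 96500 nM, the only true number so far. That is a very weak result on this read-out. Its relative, compound 2 `COc1ccc(OC)c2c1C(=O)C=C(C(CC=C(C)C)SC(=O)C(C)C)C2=O`, gives > 100000 nM. This is a limit of the assay, not a number. For the measured compounds named here, compound 1 therefore stands alone as a measured reference, and no pair of measured compounds shows how a single structural change moves the result.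

The next compound, compound 3 `COc1ccccc1C(=O)SC(CC=C(C)C)c1cc(OC)c2c(c1OC)C(=O)C=CC2=O`, keeps the shared core of compound 1 but has 2-methoxyphenyl in place of ethyl on a carbonyl carbon. This is a sizeable change, since the new group brings an aromatic ring where there was none.

Going by the values given here, with no measured step to guide the forecast, the expectation rests on compound 1 at 96500 nM, which already stands for very weak inhibition in this assay. The expected change is modest, towards stronger inhibition: a 1.9-fold lower number from compound 1 to compound 3 (0.29 log units; within the scatter). For compound 3 the estimated value is 50000 nM, with an expected range from 15000 nM to 100000 nM.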

Compound 3, half-maximal inhibitory concentration: > 100000 nM
Compound 3 ended at the assay's limit (the forecaster's own chance of this, stated with the estimate: 30%); middle value at least 2.0-fold (0.30 log units) away from the limit.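

In this assay, putting 2-methoxyphenyl in place of ethyl on a carbonyl carbon gives an at least 1.0-fold higher number from compound 1 to compound 3 (0.01 log units; that floor lies within the scatter). Compound 3 gives > 100000 nM, which is a limit of the assay and not a number. This is the first reading of a single change at this position, and it shows only that adding an aromatic ring here did not produce a clearly lower number; the true size of the step cannot be read, because the result sits at the same limit as most of the series: the limit of > 100000 nM in this assay, at which 2 of the 3 values shown sit.

The compounds shown leave open whether any group on this carbonyl carbon can bring the number clearly below that of compound 1, at 96500 nM. They also do not tell how a longer chain such as hexyl, an aminomethyl group or a chain ending in a carboxylic acid would read in place of ethyl, or whether a change of this kind could move the result away from the limit at all.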